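The source may report more compounds than this note shows. Statements on the series, on what has been measured and on what is new or still open speak of the compounds shown alone.

Compound 1 `COc1cc2nc(Nc3ccc(C#N)cc3)nc(Nc3c(Cl)cc(/C=C/C#N)cc3Cl)c2cc1OC` and compound 2 `COc1cc2nc(SCC(=O)Nc3ccc(C(F)(F)F)cc3)nc(Nc3c(Cl)cc(/C=C/C#N)cc3Cl)c2cc1OC` share much of their structure but differ in one of the groups on the shared core. In an ADME assay on MT4 cells (Homo sapiens) for cytotoxicity, read by MTT assay, with a stated time of 5 days (a lower number here means that less compound is tolerated, a higher number that more compound is tolerated), compound 1 gives 9920 nM, a true measured number. Compound 2 gives > 197000 nM, which is a limit of the assay and not a number. Where compound 2 stands is therefore known only as that limit, with no exact value to compare.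

Compound 3 `COc1cc2nc(SCC(=O)Nc3ccc(C)cc3)nc(Nc3c(Cl)cc(/C=C/C#N)cc3Cl)c2cc1OC` keeps all of compound 2 except one small group: methyl in place of trifluoromethyl on an aromatic carbon. Thus the trifluoromethyl of compound 2 becomes a methyl in compound 3, and the place of this change is para to a large group. Among the compounds with values here, no measured pair shows this swap alone, so the size of the change has to be judged from the structures. Compound 3 is expected to stay in the high range because compound 2 shows > 197000 nM, again only a limit. The estimated step of an at least 1.6-fold lower number from compound 2 to compound 3 (0.21 log units; that floor lies within the scatter) in this assay is a modest one downward, possibly no larger than the scatter. For compound 3 the expected value is 120000 nM, with an estimated range of 30000 nM to 220000 nM.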

Compound 3, half-maximal cytotoxic concentration: 2540 nM
For compound 3 the middle estimate is 47-fold (1.67 log units) above the measured one, outside the stated range (below it).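

In this assay, within the data shown here, methyl in place of trifluoromethyl on an aromatic carbon, para to a large group, gives an at least 77-fold lower number from compound 2 to compound 3 (1.88 log units; beyond the scatter), so this one small group has a large effect on how much compound the cells tolerate, which no earlier pair could show. The second step, a 3.9-fold lower number from compound 1 to compound 3 (0.59 log units; beyond the scatter), shows that the (((4-methylphenyl)carbamoyl)methyl)sulfanyl group does not by itself bring a high number, since compound 3 falls beyond the scatter below compound 1, even though it shares this chain's framework with compound 2, which differs only in trifluoromethyl. From the compounds shown here alone, compound 2 stands at a limit and not at a number, so the true size of the first step stays unknown and only its floor can be read: the limit of > 197000 nM in this assay, at which 1 of the 3 values shown sits.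

Going by these compounds, with only these two groups at this place, it remains open where a chlorine, a methoxy group or an amine there would fall. On these data alone, it also remains open whether the same swap from trifluoromethyl to methyl would move the number this far on a different chain attached to the shared core.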